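This account rests on a few compounds, and the source may have more. Where it says the series, first, only, none or still open, it means among the compounds named here.

Of the compounds shown here, three built on one shared core have been tested in a functional assay on MCF7 cells (Homo sapiens) for cytotoxicity, read by MTT assay, with a stated time of 24 h; on this read-out lower numbers stand for stronger inhibition and higher numbers for weaker inhibition. Compound 1 `Cc1cc(O)c(C(=O)/C=C/c2ccccc2)c(-c2ccc(Cl)cc2)c1C(=O)/C=C/c1ccccc1` carries a chloro group on its side ring and two unsubstituted cinnamoyl arms; in this assay compound 1 gives 15000 nM. Compound 2 `Cc1cc(O)c(C(=O)/C=C/c2ccc(Br)cc2)c(-c2ccc(OCc3ccccc3)cc2)c1C(=O)/C=C/c1ccc(Br)cc1` carries a benzyloxy group on the side ring and a bromo group on each cinnamoyl arm; in this assay compound 2 gives 30000 nM. Compound 3 `Cc1cc(O)c(C(=O)/C=C/c2ccc(F)cc2)c(-c2ccc(OCc3ccccc3)cc2)c1C(=O)/C=C/c1ccc(F)cc1` keeps the benzyloxy group and has a fluoro group on each arm; in this assay compound 3 gives 28000 nM. Compound 2 has the highest of the three numbers, but its gap to compound 3 and its gap to compound 1 are both within the usual scatter, so the three values cannot be told apart.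

Compound 4 `Cc1cc(O)c(C(=O)/C=C/c2ccc(Br)cc2)c(-c2ccccc2)c1C(=O)/C=C/c1ccc(Br)cc1` differs from compound 2 in one place: hydrogen in place of benzyloxy on an aromatic carbon. Among the compounds with values here, no measured pair in this set shows the effect of this exact change, and the three measured values sit close together, so no step beyond the scatter is expected. The step from compound 2 to compound 4 is estimated at a 1.4-fold lower number from compound 2 to compound 4 (0.13 log units; within the scatter). Compound 4 is expected to give about 22000 nM, with a likely range from 9000 nM to 55000 nM.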

Compound 4, half-maximal inhibitory concentration: 10000 nM
Estimate against measurement, compound 4: 2.2-fold (0.34 log units) above, within the range that was stated.
By their numbers in this assay, from the lowest: compounds 4, 1, 3 and 2 (each within the scatter of the next, the first and the last beyond it).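

In this assay, within the data shown here, the exchange of benzyloxy for hydrogen gives a 3.0-fold lower number from compound 2 to compound 4 (0.48 log units; beyond the scatter) and is the only step in this set that can be read, since the earlier compounds all differ in more than one place. This is modest, but it lies beyond the scatter, so this position on the side ring does affect the read-out, at least when both cinnamoyl arms carry bromo. The benzyloxy group is also not needed for activity in this pair: compound 4 loses that whole group, with its extra aromatic ring, and its number is lower rather than higher. Nothing measured here explains why the number falls.

The compounds shown leave open how a smaller group at this place, such as methoxy, hydroxyl or an amine, would compare with hydrogen and with benzyloxy. They also leave open whether the same change would produce a similar step on compound 3 with its fluoro arms, as this single pair covers only the bromo arms.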